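Swapping the Aryl Group on a Terpene Thiosemicarbazone

The source may hold more compounds than are shown below. What is called first, only, known or untested is meant among the compounds shown, and "the series" means these compounds.

Compound 1 `CC1=CC[C@@H]([C@@](C)(O)CCCC(C)(C)NC(=S)N/N=C\c2ccc(C)cc2)CC1`: 80400 nM
Compound 2 `CC1=CC[C@@H]([C@@](C)(O)CCCC(C)(C)NC(=S)N/N=C\c2ccc(N(C)C)cc2)CC1`: a limit of the assay, > 100000 nM
Compound 3 `CC1=CC[C@@H]([C@@](C)(O)CCCC(C)(C)NC(=S)N/N=C\c2cccc([N+](=O)[O-])c2)CC1`: 57100 nM

In a functional assay on HT-29 cells (Homo sapiens) for cytotoxicity, read by sulforhodamine B assay (a lower number here means a stronger inhibitor of growth, a higher number a weaker inhibitor of growth), compound 3 holds the lowest of the two numbers; the nearest is compound 1, and that gap, a 1.4-fold lower number from compound 1 to compound 3 (0.15 log units; within the scatter), stays within the scatter. Compound 4 `CC1=CC[C@@H]([C@@](C)(O)CCCC(C)(C)NC(=S)N/N=C\c2ccccc2Cl)CC1` brings a further aryl swap: 2-chlorophenyl in place of 3-nitrophenyl on a carbon with a double bond to nitrogen. The aryl changes measured so far moved the read-out little: a 1.4-fold lower number from compound 1 to compound 3 (0.15 log units; within the scatter), an at least 1.7-fold lower number from compound 2 to compound 3 (0.24 log units; that floor lies within the scatter) and an at least 1.2-fold higher number from compound 1 to compound 2 (0.09 log units; that floor lies within the scatter), the last two bounded by the limit of > 100000 nM in this assay, at which 1 of the 3 values shown sits. No step beyond the scatter is therefore expected, a 1.1-fold higher number from compound 3 to compound 4 (0.02 log units; within the scatter). Compound 4 is estimated at 60000 nM, with a range from 25000 nM to 150000 nM.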

Compound 4, concentration for total growth inhibition: > 100000 nM
Compound 4 was reported as a limit; the forecaster's own chance of this, stated with the estimate: 30%; at least 1.6-fold (0.22 log units) between middle value and limit.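

A chlorine-bearing ring on the carbon with a double bond to nitrogen also brings no step beyond the scatter in this assay: the floors are an at least 1.7-fold higher number from compound 3 to compound 4 (0.24 log units; that floor lies within the scatter) and an at least 1.2-fold higher number from compound 1 to compound 4 (0.09 log units; that floor lies within the scatter). Each floor could hide a larger step, as compound 4 is reported only as a limit. Compound 2 and compound 4 both stand at a limit, so the step between them cannot be read: the limit of > 100000 nM in this assay, at which 2 of the 4 values shown sit.

Still open, going by these compounds, is how far compound 4 lies past that limit. On these data alone, it is also open whether a carboxylic acid or a primary amine on this aryl ring would give a clearly different number.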